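Amide swap on a hexafluoro-propanol naphthylamide series

The source may hold more compounds than are shown below. What is called first, only, known or untested is meant among the compounds shown, and "the series" means these compounds.

Three amides sharing one core have been measured in an assay on LtK cells with ATP-sensitive inward rectifier potassium channel 11 (Homo sapiens) as the target; a lower number here means that less compound is needed, a higher number that more compound is needed for the effect. Compound 1 `CCC(=O)Nc1c(C(O)(C(F)(F)F)C(F)(F)F)ccc2ccccc12` gives 15 nM, compound 3 `Cc1cccc(C(=O)Nc2c(C(O)(C(F)(F)F)C(F)(F)F)ccc3ccccc23)c1` gives 23 nM, and compound 2 `O=C(Nc1c(C(O)(C(F)(F)F)C(F)(F)F)ccc2ccccc12)C1CC1` gives 751 nM, the highest number of the three: its nearest neighbour is a 33-fold lower number from compound 2 to compound 3 (1.51 log units; beyond the scatter), its furthest a 50-fold higher number from compound 1 to compound 2 (1.70 log units; beyond the scatter), while a 1.5-fold higher number from compound 1 to compound 3 (0.19 log units; within the scatter) stays within the scatter. Compound 4 `COc1cccc(C(=O)Nc2c(C(O)(C(F)(F)F)C(F)(F)F)ccc3ccccc23)c1` has not yet been measured; it differs from compound 2 in one place (3-methoxyphenyl in place of cyclopropyl on a carbonyl carbon). The measured step that bears directly on this change is the move from cyclopropyl to 3-methylphenyl, a 33-fold lower number from compound 2 to compound 3 (1.51 log units; beyond the scatter), a large drop; the aromatic amides compound 1 and compound 3 sit close together. Since compound 4 carries an aromatic amide of the same kind as compound 3, a large drop of comparable size is expected, a 25-fold lower number from compound 2 to compound 4 (1.40 log units; beyond the scatter), with no reason in the data to expect the methoxy group to alter that. Compound 4 is therefore estimated at 30 nM, between 8 nM and 120 nM.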

Compound 4, half-maximal effective concentration: 185 nM
Compound 4: the middle estimate sits 6.2-fold (0.79 log units) below what was measured; the whole stated range lies below it.
By their numbers in this assay, from the lowest: compounds 1 and 3 (each within the scatter of the next); then compound 4; then compound 2.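

In this assay, methoxy in place of methyl on an aromatic carbon gives an 8.0-fold higher number from compound 3 to compound 4 (0.91 log units; beyond the scatter) and shows that an aromatic amide alone does not secure a low number, since the group on that ring also counts. The 3-methoxyphenyl amide still improves on cyclopropyl with a 4.1-fold lower number from compound 2 to compound 4 (0.61 log units; beyond the scatter) but does not match ethyl, as seen in a 12-fold higher number from compound 1 to compound 4 (1.09 log units; beyond the scatter) even though 3-methylphenyl and ethyl stand within the scatter of each other. Nothing measured here accounts for the difference between methoxy and methyl.

Going by these compounds, it remains open whether a chloro, hydroxy or ethyl group on that aromatic carbon would behave like methyl or like methoxy. Nor do these compounds show how a longer chain such as propyl or butyl on the carbonyl carbon would compare with ethyl.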